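The source may hold more compounds than are shown below. What is called first, only, known or untested is meant among the compounds shown, and "the series" means these compounds.

Measured so far:
compound 1, `Nc1nc(Cl)c2ncn(Cc3ccccc3CCl)c2n1`: 8910 nM
compound 2, `Nc1nc(Cl)c2ncn(Cc3cccc(CCl)c3)c2n1`: 5010 nM

The two measured compounds share one core and differ only in where the chloromethyl group sits on the benzyl ring. In a functional assay on NCI-H23 cells (Homo sapiens) for cytotoxicity, read by sulforhodamine B assay, with a stated time of 48 h (a lower number here means a stronger inhibitor of growth, a higher number a weaker inhibitor of growth), compound 1 gives 8910 nM, the highest of the two numbers. In this assay compound 2 gives 5010 nM, and the two values lie within the scatter of each other, so no order between them can be read from these data.

The next compound is compound 3, `ClCc1ccccc1Cn1cnc2c(Cl)ncnc21`, which stands to compound 1 as follows: hydrogen in place of amino on an aromatic carbon. The change sits on an aromatic carbon of the core, between two ring nitrogen atoms, meta to a chloro group.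

Among the compounds with values here, no measured pair shows this change, so its size cannot be taken from the data. Compound 3 is expected to give 12000 nM in this assay, with a range from 4000 nM to 40000 nM. The step this estimate means, a 1.3-fold higher number from compound 1 to compound 3 (0.13 log units; within the scatter), is expected to be small, toward a higher number, possibly not beyond the scatter.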

Compound 3, concentration for total growth inhibition: 4360 nM
Compound 3: middle estimate off by 2.8-fold (0.44 log units), on the high side; the measured number falls inside the stated range.
By their numbers in this assay, from the lowest: compounds 3, 2 and 1 (each within the scatter of the next, the first and the last beyond it).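

In this assay, within the data shown here, putting hydrogen in place of amino on the aromatic carbon between two ring nitrogen atoms gives a 2.0-fold lower number from compound 1 to compound 3 (0.31 log units; beyond the scatter), the first change at this position whose size can be read from the data. The step is modest, but it lies beyond the scatter and points toward stronger inhibition of growth, so the amino group of compound 1 is not required for the growth inhibition seen in this pair. Nothing at hand bears on why the number moves this way, and the reason remains unknown.

What the compounds shown leave open is whether this step belongs to the position in general or only to the chloromethyl placement shared by compound 1 and compound 3, since the same change has yet to be seen with the chloromethyl group placed as in compound 2. They also leave open how other groups on this aromatic carbon would compare with amino and hydrogen, such as a methylamino group, a hydroxyl group or a methyl group, and so whether the trend continues beyond this single pair.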